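Swapping a branched chain for a small nitrogen ring

The compounds below may be only part of what the source reports. "The series", "measured", "known", "first", "only" and "open" are said of these compounds alone.

Compound 1 `CCn1nc(C(=O)N[C@H]2COc3ccccc3N(C)C2=S)nc1Cc1ccccc1` is the reference point of this set. In a functional assay on HT-29 cells (Homo sapiens) for inhibition, read by luminescence and CellTiter-Glo, with a stated time of 24 h (on this read-out lower numbers stand for an effect already at smaller amounts and higher numbers for an effect only at larger amounts of compound), compound 1 gives 17 nM. Compound 2 `CC(C)CCn1nc(C(=O)N[C@H]2COc3ccccc3N(C)C2=S)nc1Cc1ccccc1` gives 3640 nM, and compound 3 `COCCn1nc(C(=O)N[C@H]2COc3ccccc3N(C)C2=S)nc1Cc1ccccc1` gives 566 nM. Among these three numbers compound 2 stands highest: the step of a 210-fold higher number from compound 1 to compound 2 (2.33 log units; beyond the scatter) is the largest in the set, and the step of a 6.4-fold lower number from compound 2 to compound 3 (0.81 log units; beyond the scatter) is smaller but still clear, while a 33-fold higher number from compound 1 to compound 3 (1.52 log units; beyond the scatter) sits between them in size. Every change here is made at the same saturated chain carbon, two bonds along the chain from the aromatic nitrogen, and the larger or more branched the group placed there, the higher the number has come out.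

Compound 4 `CN1C(=S)[C@@H](NC(=O)c2nc(Cc3ccccc3)n(C3CCNC3)n2)COc2ccccc21` changes the same region more deeply: pyrrolidin-3-yl in place of isopentyl on an aromatic nitrogen. Within the data shown here, no measured step replaces the whole chain with a ring, so the nearest guide is a 6.4-fold lower number from compound 2 to compound 3 (0.81 log units; beyond the scatter), which shows that moving away from the isopentyl chain lowered the number, together with a 210-fold higher number from compound 1 to compound 2 (2.33 log units; beyond the scatter), which shows how much that chain had raised it. A step downward is therefore expected, a 6.1-fold lower number from compound 2 to compound 4 (0.78 log units; beyond the scatter), though its size is uncertain. Compound 4 is estimated at 600 nM, with a likely range from 100 nM to 3600 nM.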

Compound 4, half-maximal effective concentration: 1070 nM
Estimate against measurement, compound 4: 1.8-fold (0.25 log units) below, and the stated range covers the measured number.
By their numbers in this assay, from the lowest: compound 1; then compounds 3 and 4 (each within the scatter of the next); then compound 2.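

Pyrrolidin-3-yl and isopentyl have the same number of heavy atoms, yet the result is a 3.4-fold lower number from compound 2 to compound 4 (0.53 log units; beyond the scatter) on the aromatic nitrogen, so in compound 2 and compound 4 group size alone does not set the number. Replacing the open 2-methoxyethyl chain with the ring gives a 1.9-fold higher number from compound 3 to compound 4 (0.28 log units; within the scatter) and thus no order between them, showing that two quite different groups can land in the same range here. Ethyl remains clearly apart, with a 63-fold higher number from compound 1 to compound 4 (1.80 log units; beyond the scatter) even though the ring-bearing compound 4 sits well under compound 2, and no measurement shown here explains these differences.

The swap from isopentyl to pyrrolidin-3-yl brings in a ring, a ring nitrogen and a hydrogen-bond donor all at once, so the compounds shown cannot separate what each contributes; a cyclopentyl group, which keeps the ring without the nitrogen, or a straight chain ending in an amine would pull those apart. Going by these compounds, whether a methyl group, smaller than the ethyl of compound 1, would lower the number further also stays open.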